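Phenylurea series: trifluoromethyl to fluoro on the aryl ring

A few compounds are considered here, and "the series" means these few. Any claim that something is new, unique, unknown or untested is made for them only; others in the source may bear on it.

Measured so far:
compound 1 `C[C@@H](NC(=O)Nc1cccc(C(F)(F)F)c1)c1ccccc1`, 82%
compound 2 `C[C@H](NC(=O)Nc1cccc(C(F)(F)F)c1)c1ccccc1`, 94%
compound 3 `C[C@H](NC(=O)Nc1ccc(C(F)(F)F)cc1)c1ccccc1`, 94%

In an ADME assay on the whole organism with Oryza sativa as the target, tested at 0.1 uM (on this read-out lower numbers stand for a stronger effect and higher numbers for a weaker effect at the one concentration tested), compound 1 gives 82%, the lowest of the three numbers; compound 2 and compound 3 both sit above it, each by a step beyond the scatter. Going by the values given here, the only single-point step measured is a number 12 percentage points higher from compound 1 to compound 2 (beyond the scatter), which rests on the fact that compounds 1 and 2 differ only in the configuration as drawn alone and touches no substituent. Compound 3 differs from compound 2 in where the trifluoromethyl sits, and the two give the same number.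

Compound 4 `C[C@@H](NC(=O)Nc1cccc(F)c1)c1ccccc1` is the next step from compound 1: fluoro in place of trifluoromethyl on an aromatic carbon, on an aromatic carbon of a six-membered aromatic ring of carbon only. Among the compounds with values here, no measured step changes this group or any group, so nothing here bears directly on the change. Within the data shown here, the one modest step known moves the number upward from compound 1, and compound 1 already stands at the low end of the set, so a modest rise is the more likely outcome. Compound 4 is therefore expected to give 88%, between 74% and 98%, meaning an estimated step of a number 6 percentage points higher from compound 1 to compound 4 (within the scatter).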

Compound 4, a percentage reported as activity, at one concentration (the size of the read-out at that concentration, not a potency): 99%
Estimate against measurement, compound 4: 11 percentage points below; the whole stated range lies below it.
By their numbers in this assay, from the lowest: compound 1; then compounds 2, 3 and 4 (each within the scatter of the next).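

In this assay, going by these compounds alone, the group on this aromatic carbon matters as well as the stereocentre: fluoro in place of trifluoromethyl gives a number 17 percentage points higher from compound 1 to compound 4 (beyond the scatter) and is the first measured step that changes a substituent. This step runs in the same upward direction as a number 12 percentage points higher from compound 1 to compound 2 (beyond the scatter) and so compound 1 holds the lower number in both single-place comparisons. Nothing available accounts for the step from trifluoromethyl to fluoro.

On these data alone, whether an amine, a carboxylic acid or a methoxy group on this carbon would give a number closer to that of compound 1 or to that of compound 4 stays open. Also open, as far as these compounds go, is whether fluoro in place of trifluoromethyl gives a similar step in the opposite configuration as drawn.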